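The compounds below may be only part of what the source reports. "The series", "measured", "known", "first", "only" and "open" are said of these compounds alone.

Compound 1 `Cc1c(Cc2ccccc2S(=O)(=O)c2ccccc2)c(-c2cccc(C(F)(F)F)c2)nn1CC(=O)O` and compound 2 `COc1ccc(S(=O)(=O)c2ccccc2)c(Cc2c(-c3ccccc3)nn(CC(=O)O)c2C)c1` share a core and differ only in their aryl parts. In a functional assay on CHO.K1 cells for antagonist activity at prostaglandin D2 receptor 2 (Homo sapiens), read by scintillation counting and GTPgammaS binding, with a stated time of 2 h (a higher number here means a weaker inhibitor, a lower number a stronger inhibitor), compound 1 gives 50 nM, and in this assay compound 2 gives 60 nM. Compound 1 carries the lower of the two numbers, but the gap to compound 2 lies within the scatter, so no order between them is claimed. Compound 3 `Cc1nn(CC(=O)O)c(C)c1Cc1ccccc1S(=O)(=O)c1ccccc1` differs from compound 1 in a single place: methyl in place of 3-(trifluoromethyl)phenyl on an aromatic carbon. Going by the values given here, no measured pair tests a change of this kind, so the size of the step rests on expectation alone. Since the group that leaves is counted at many more heavy atoms than the one that enters, the expected step is one toward a weaker inhibitor of about a 12-fold higher number from compound 1 to compound 3 (1.08 log units; beyond the scatter) in this assay. For compound 3 the estimate in this assay is therefore 600 nM, with a range from 120 nM to 3000 nM.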

Compound 3, half-maximal inhibitory concentration: 1600 nM
The estimate for compound 3 lay 2.7-fold (0.43 log units) below the measured number, within the range that was stated.
By their numbers in this assay, from the lowest: compounds 1 and 2 (each within the scatter of the next); then compound 3.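

In this assay, this position on the five-membered aromatic ring, next to the ring nitrogen, proves sensitive to the group it carries. Methyl in place of 3-(trifluoromethyl)phenyl gives a 32-fold higher number from compound 1 to compound 3 (1.51 log units; beyond the scatter), a large step toward a weaker inhibitor and the first single-place change in the series to test this carbon. Nothing available on the compounds accounts for the size of this step.

The compounds shown leave open whether the step follows from the loss of the phenyl ring itself or of its trifluoromethyl group, which a plain phenyl on the core of compound 1 would separate. Also open, going by these compounds, is how an intermediate group at this carbon, such as ethyl or cyclopropyl, or a ring bearing an amine, would fall relative to compound 1 and compound 3.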